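Swapping the Aryl Group on the Five-Membered Ring

The compounds below may be only part of what the source reports. "The series", "measured", "known", "first", "only" and "open" are said of these compounds alone.

Of the compounds shown here, three sharing one core have been tested in an assay for inhibition of Polyunsaturated fatty acid 5-lipoxygenase (Homo sapiens), read by HPLC, with a stated time of 10 min; a lower number here means a stronger inhibitor, a higher number a weaker inhibitor. Compound 1 `O=C(O)CSc1nc(Cl)cc(Nc2nc(-c3ccc(Cl)cc3)cs2)n1` lacks the naphthalenyl group that compound 2 `O=C(O)C(Sc1nc(Cl)cc(Nc2nc(-c3ccc(Cl)cc3)cs2)n1)c1cccc2ccccc12` carries. For compound 1 this assay reports only a limit, > 10000 nM. Within the data shown here, compound 2 gives 700 nM, and the step of an at least 14-fold lower number from compound 1 to compound 2 (1.15 log units; beyond the scatter) is the only single-point change measured so far. Compound 3 `CCCCCCC(Sc1nc(Cl)cc(Nc2nc(-c3cccc4ccccc34)cs2)n1)C(=O)O` arranges its groups differently and gives 700 nM, level with compound 2. Compound 4 `CCCCCCC(Sc1nc(Cl)cc(Nc2nc(-c3ccc([N+](=O)[O-])cc3)cs2)n1)C(=O)O` differs from compound 3 by 4-nitrophenyl in place of naphthalen-1-yl on an aromatic carbon. Among the measured compounds shown here, no measured step touches this position, so the one measured step offers no guide, and the expected step of a 1.4-fold higher number from compound 3 to compound 4 (0.15 log units; within the scatter) is modest. Compound 4 is therefore estimated at 1000 nM, within 300 nM to 4000 nM.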

Compound 4, half-maximal inhibitory concentration: 1800 nM
Compound 4: the middle estimate sits 1.8-fold (0.26 log units) below what was measured, and the stated range covers the measured number.
By their numbers in this assay, from the lowest: compounds 2 and 3 (each within the scatter of the next); then compound 4. At a limit, above all of these: compound 1.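

In this assay the first step measured at this position is a 2.6-fold higher number from compound 3 to compound 4 (0.41 log units; beyond the scatter) and it shows that the number responds to the choice of aryl group here. The step is only modest, even though one-ring 4-nitrophenyl, with its two hydrogen-bond acceptors, replaces two-ring naphthalen-1-yl. Nothing measured here accounts for the step.

These two compounds cannot separate the loss of the second ring from the arrival of the nitro group. A plain phenyl or a 4-aminophenyl group at this position would help to tell the two apart.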